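Swapping a Methoxy for a Phenyl on the Shared Core

A few compounds are considered here, and "the series" means these few. Any claim that something is new, unique, unknown or untested is made for them only; others in the source may bear on it.

Of the compounds shown here, three with one shared core have been measured in an assay on HepG2 cells for agonist activity at nuclear receptor subfamily 1 group I member 3 (Homo sapiens), read by a luciferase reporter, with a stated time of 23 h; a higher number here means that more compound is needed for the effect, a lower number that less compound is needed. Compound 1 `Clc1ccc(CO/N=C/c2c(-c3ccc(Br)cc3)nc3sccn23)cc1Cl` gives 480 nM. Compound 2 `CC(C)c1ccc(-c2nc3sccn3c2/C=N/OCc2ccc(Cl)c(Cl)c2)cc1` gives 590 nM. Compound 3 `COc1ccc(-c2nc3sccn3c2/C=N/OCc2ccc(Cl)c(Cl)c2)cc1` gives 490 nM. Compound 3 thus stands second highest of the three numbers, yet the steps around it are small: a 1.0-fold higher number from compound 1 to compound 3 (0.01 log units; within the scatter), a 1.2-fold lower number from compound 2 to compound 3 (0.08 log units; within the scatter), and for the remaining pair a 1.2-fold higher number from compound 1 to compound 2 (0.09 log units; within the scatter). Every exchange at that aromatic carbon has left the number within the scatter.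

Compound 4 `Clc1ccc(CO/N=C/c2c(-c3ccc(-c4ccccc4)cc3)nc3sccn23)cc1Cl` has not yet been measured. It differs from compound 3 by phenyl in place of methoxy on an aromatic carbon. All three measured steps bear on this change, as each swaps one group at the same aromatic carbon, and none moved the number beyond the scatter. A phenyl group brings more atoms than anything tried there so far, and the measured steps give no direct check on a group of that size. Still, the step from compound 3 to compound 4 is expected to be small, a 1.0-fold higher number from compound 3 to compound 4 (0.01 log units; within the scatter). In this assay compound 4 is estimated at 500 nM, with a likely range from 200 nM to 1500 nM.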

Compound 4, half-maximal effective concentration: "not active" (no number reported)
For compound 4 the study gives words and no number, so the estimate cannot be set against anything.
By their numbers in this assay, from the lowest: compounds 1, 3 and 2 (each within the scatter of the next).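

Among these compounds, compound 4 is reported only as "not active", without a number, so no step from compound 3 or any other compound to compound 4 can be read. The compounds shown leave open whether a group smaller than phenyl but larger than those in compounds 1, 2 and 3 would still give a number at that aromatic carbon. No measurement shown here offers an explanation for the "not active" result.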